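The compounds below may be only part of what the source reports. "The series", "measured", "known", "first", "only" and "open" are said of these compounds alone.

Measured so far:
- compound 1, `Cc1ccc(-c2cs/c(=N/NC(=O)CSc3nncn3C)n2-c2ccccc2)cc1`: 130 ug/mL
- compound 2, `Cn1cnnc1SCC(=O)N/N=c1/scc(-c2ccc(Br)cc2)n1-c1ccccc1`: 58.3 ug/mL

In an ADME assay on NIH3T3 cells (Mus musculus) for cytotoxicity, read by MTT assay, with a stated time of 24 h (a higher number here means a weaker inhibitor, a lower number a stronger inhibitor), compound 1 gives the higher of the two numbers recorded; its nearest neighbour is compound 2, and the step of a 2.2-fold lower number from compound 1 to compound 2 (0.35 log units; beyond the scatter) comes with bromo in place of methyl on an aromatic carbon. Compound 3, `Cc1ccc(-c2cs/c(=N/NC(=O)CSc3nnc(C)s3)n2-c2ccccc2)cc1`, has not yet been measured. It differs from compound 1 in one place: 5-methyl-1,3,4-thiadiazol-2-yl in place of 4-methyl-4H-1,2,4-triazol-3-yl on a sulfur. For the measured compounds named here, the only measured step, from compound 1 to compound 2, alters a different part of the shared core and so says nothing directly about exchanging the ring on the sulfur; no measured pair speaks to that change. With nothing in the numbers pointing up or down, the step of a 1.1-fold lower number from compound 1 to compound 3 (0.03 log units; within the scatter) is expected to stay within the scatter. Compound 3 is therefore estimated at 120 ug/mL in this assay, with a range from 55 ug/mL to 260 ug/mL.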

Compound 3, half-maximal inhibitory concentration: 373 ug/mL
Compound 3: the middle estimate sits 3.1-fold (0.49 log units) below what was measured, outside the stated range (above it).
By their numbers in this assay, from the lowest: compound 2; then compound 1; then compound 3.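

In this assay, the ring on the sulfur proves to be a position that registers: 5-methyl-1,3,4-thiadiazol-2-yl in place of 4-methyl-4H-1,2,4-triazol-3-yl goes with a 2.9-fold higher number from compound 1 to compound 3 (0.46 log units; beyond the scatter) even though the two rings match in heavy atoms and in counted hydrogen-bond donors and acceptors. The earlier step, a 2.2-fold lower number from compound 1 to compound 2 (0.35 log units; beyond the scatter) with bromo in place of methyl on an aromatic carbon, ran the other way, so changes in these two places move the number from compound 1 in opposite directions. Nothing at hand explains why this ring exchange shifts the number.

The ring atoms and the place of the methyl change together, so the compounds shown leave open which of them carries the step. They also leave open how a carboxylic acid or an amine on the sulfur would read, and whether bromo in place of methyl would act the same way alongside the 5-methyl-1,3,4-thiadiazol-2-yl group.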